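Lipophilicity of a pyrazinyl sulfonamide estimated from three analogues

This account rests on a few compounds, and the source may have more. Where it says the series, first, only, none or still open, it means among the compounds named here.

Three compounds have been measured in a physicochemical assay for lipophilicity; on this read-out higher numbers stand for higher lipophilicity and lower numbers for lower lipophilicity:
compound 1 `O=C1OCCN1c1cc(C(F)(F)F)ccc1[C@H]1CCOc2cc(S(=O)(=O)Nc3nccs3)ccc21` gives 2.1;
compound 2 `Cn1nccc1-c1cc(C(F)(F)F)ccc1[C@H]1CCOc2cc(S(=O)(=O)Nc3nccs3)ccc21` gives 2.2;
compound 3 `O=S(=O)(Nc1nccs1)c1ccc2c(c1)OCC[C@@H]2c1ccc(C(F)(F)F)cc1-c1ccc(F)nc1` gives 3.2.

Compound 2 stands close to compound 1, the two differing by a number 0.10 log units higher from compound 1 to compound 2 (within the scatter), and the gap to compound 3 is a number 1.00 log units higher from compound 2 to compound 3 (beyond the scatter). Compound 1 and compound 3 differ by a number 1.10 log units higher from compound 1 to compound 3 (beyond the scatter). All three measured steps exchange the group on an aromatic carbon of the shared core; none touches the sulfonamide nitrogen.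

Compound 4 `Cn1nccc1-c1cc(C(F)(F)F)ccc1[C@H]1CCOc2cc(S(=O)(=O)Nc3cnccn3)ccc21` is not yet measured. The change from compound 2 is pyrazin-2-yl in place of 1,3-thiazol-2-yl on a sulfonamide nitrogen. Among the compounds with values here, no measured step bears directly on this position, so the expectation rests only on the count of atoms and ring type given for the leaving and entering groups, which are of similar size with equal hydrogen-bond acceptor counts. Compound 4 is therefore expected to show only a small step in this assay, a number 0.30 log units lower from compound 2 to compound 4 (within the scatter), which may not exceed the scatter. Compound 4 is estimated at 1.9, in the range 1.4 to 2.4.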

Compound 4, distribution coefficient: 1.8
Beside the measured number, compound 4's estimate is 0.10 log units above it, and the stated range covers the measured number.
By their numbers in this assay, from the lowest: compounds 4, 1 and 2 (each within the scatter of the next, the first and the last beyond it); then compound 3.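

Within the data shown here, the exchange of 1,3-thiazol-2-yl for pyrazin-2-yl on a sulfonamide nitrogen is the first change at this position that can be read in this assay, and it comes to a number 0.40 log units lower from compound 2 to compound 4 (beyond the scatter). The earlier steps shown here all lay on an aromatic carbon, so this one shows that the read-out also responds to the group on the sulfonamide nitrogen, even though the two rings carry the same count of hydrogen-bond acceptors and no net charge. No measurement at hand gives a reason for this step.

The compounds shown leave open whether the exchange gives a step of like size with 2-oxo-1,3-oxazolidin-3-yl or 6-fluoropyridin-3-yl on the aromatic carbon. They also leave open where a phenyl ring or a methyl group on the sulfonamide nitrogen would fall in this assay.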